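A bromo for methoxy swap on a weakly cytotoxic core

This account rests on a few compounds, and the source may have more. Where it says the series, first, only, none or still open, it means among the compounds named here.

compound 1 `COc1ccc(Nc2nc(-c3cccc(F)c3)nc3ccc(F)cc23)cc1`: 38600 nM
compound 2 `Fc1cccc(-c2nc(Nc3cccc(Cl)c3)c3cc(F)ccc3n2)c1`: > 50000 nM
compound 3 `Fc1cccc(-c2nc(Nc3ccccc3Cl)c3cc(F)ccc3n2)c1`: > 50000 nM

Within the data shown here, in a functional assay on HL-60 cells (Homo sapiens) for cytotoxicity, read by MTT assay, with a stated time of 48 h (a higher number here means a weaker inhibitor, a lower number a stronger inhibitor), compound 1 gives 38600 nM, and this is the only number among the three values shown. For compound 2 the value > 50000 nM is a limit of the assay, not a number. For compound 3 the value > 50000 nM is likewise a limit. Two of the three values thus sit at the limit of > 50000 nM in this assay, at which 2 of the 3 values shown sit. Among the measured compounds shown here, the steps read an at least 1.2-fold higher number from compound 1 to compound 2 (0.11 log units; that floor lies within the scatter) and an at least 1.2-fold higher number from compound 1 to compound 3 (0.11 log units; that floor lies within the scatter), so compound 1 stands as the one compound with a readable number, though neither step is readable beyond the scatter. The step that the two limits leave unreadable from compound 2 to compound 3 is not readable either.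

Compound 4 `Fc1cccc(-c2nc(Nc3ccc(Br)cc3)c3cc(F)ccc3n2)c1` differs from compound 1 by bromo in place of methoxy on an aromatic carbon. For the measured compounds named here, no measured step makes exactly this change; the two halogen-bearing analogues both reached the limit, which is what bears on it. Compound 4 is therefore expected at 50000 nM, within 25000 nM to 100000 nM. The step that this estimate means is expected to read a 1.3-fold higher number from compound 1 to compound 4 (0.11 log units; within the scatter), a weakening likely to end at the limit.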

Compound 4, half-maximal inhibitory concentration: > 50000 nM
Compound 4 was reported as a limit; the forecaster's own chance of this, stated with the estimate: 55%; the middle value sits exactly at the limit.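

Compounds 2 and 3 changed both the group and its place on the ring, whereas compound 4 keeps the place of the methoxy and changes only the group. In this assay, bromo in place of methoxy gives an at least 1.2-fold higher number from compound 1 to compound 4 (0.11 log units; that floor lies within the scatter), so even this single change at that position cannot be read as a real loss, and the value of compound 4 is a limit, not a number. The steps from compounds 2 and 3 to compound 4 cannot be read, and compound 1 remains the only compound with a number: the limit of > 50000 nM in this assay, at which 3 of the 4 values shown sit.

Among these compounds, no step from compound 1 reads beyond the scatter, so whether the methoxy matters at all stays open. Also open, going by these compounds, is where a hydroxyl or an amine at this position would stand in this assay.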